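Hydroxy removal on the amine side chain: cytotoxicity

The compounds below may be only part of what the source reports. "The series", "measured", "known", "first", "only" and "open" are said of these compounds alone.

compound 1 `CNC(c1ccc(/C=C/C#N)cc1)c1ccnc(Nc2ccc(C#N)cc2)n1`: 41400 nM
compound 2 `CC(O)CNC(c1ccc(C#N)cc1)c1ccnc(Nc2ccc(C#N)cc2)n1`: > 65000 nM

In an ADME assay on MT4 cells (Homo sapiens) for cytotoxicity, read by MTT assay, with a stated time of 5 days (a lower number here means that less compound is tolerated, a higher number that more compound is tolerated), compound 1 gives 41400 nM. Compound 2 gives only a limit, > 65000 nM, which is the limit of > 65000 nM in this assay, at which 1 of the 2 values shown sits. Compound 2 thus stands at the edge of what this assay reports, with no number of its own. Compound 3 `CCCNC(c1ccc(C#N)cc1)c1ccnc(Nc2ccc(C#N)cc2)n1` differs from compound 2 by hydrogen in place of hydroxy on a saturated chain carbon bound to two saturated chain carbons. Going by the values given here, no step between measured compounds is available; in this assay a step from compound 2 to compound 3 within the scatter is expected, direction unknown. Compound 3 is expected to give 60000 nM, between 20000 nM and 130000 nM. The expected step of an at least 1.0-fold lower number from compound 2 to compound 3 (0.03 log units; that floor lies within the scatter) therefore stays within the scatter.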

Compound 3, half-maximal cytotoxic concentration: 34900 nM
Compound 3: middle estimate off by 1.7-fold (0.24 log units), on the high side, within the range that was stated.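

In this assay, going by these compounds alone, the removal of hydroxy from this saturated chain carbon gives an at least 1.8-fold lower number from compound 2 to compound 3 (0.27 log units; that floor lies within the scatter) as the first reading for this change. From the compounds shown here alone, compound 2 carries a limit, so only a floor for the step can be read and its full size stays unknown: the limit of > 65000 nM in this assay, at which 1 of the 3 values shown sits.

Going by these compounds, whether the step reaches beyond the scatter remains open. Also open, on these data alone, is how methoxy or an amine on the same saturated chain carbon, or a longer chain in place of propyl, would read in this assay on the shared core.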